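A Ring Swap at the Assay Limit

The source may report more compounds than this note shows. Statements on the series, on what has been measured and on what is new or still open speak of the compounds shown alone.

Compound 1 `COc1cc(-c2ncnn2-c2cccc(F)c2)cc(OC)c1OC` was tested in a functional assay on HeLa cells (Homo sapiens) for antiproliferative activity, read by MTT assay, with a stated time of 72 h; a lower number here means a stronger inhibitor, a higher number a weaker inhibitor. Compound 1 gives > 10000 nM, which is a limit and not a number. That places it at the limit of > 10000 nM in this assay, at which 2 of the 3 values shown sit. Compound 2 `COc1cc(-n2ncnc2-c2ccc(Cl)c(Cl)c2)cc(OC)c1OC` gives > 10000 nM, which is also a limit. Compound 3 `CCOc1ccc(-c2ncnn2-c2cc(OC)c(OC)c(OC)c2)cc1` gives a true number, 15 nM, and it carries neither 3-fluorophenyl nor 3,4-dichlorophenyl.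

Compound 4 `COc1cc(-c2ncnn2-c2ccc(Cl)c(Cl)c2)cc(OC)c1OC` has not yet been measured. It has 3,4-dichlorophenyl in place of 3-fluorophenyl on an aromatic nitrogen. Among the compounds with values here, no measured pair shows what a single change of this kind does in this assay. Compound 2 also carries 3,4-dichlorophenyl, and because compound 2 reads > 10000 nM no step beyond the scatter is expected, so a reading at the limit seems most likely. The expected change is a step that the limit leaves unreadable from compound 1 to compound 4. For compound 4 the estimated value is 12000 nM, with an expected range from 3000 nM to 30000 nM.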

Compound 4, half-maximal inhibitory concentration: > 10000 nM
Compound 4 gave a limit, no number (the forecaster's own chance of this, stated with the estimate: 75%); the middle value lies beyond the limit too.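

Compound 1 and compound 4 are both limits and not numbers, so no step between them can be read: the limit of > 10000 nM in this assay, at which 3 of the 4 values shown sit.

Whether 3,4-dichlorophenyl in place of 3-fluorophenyl changes activity at all stays open, and no pair shown ties the measured number of compound 3 to any single change.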